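The source may report more compounds than this note shows. Statements on the series, on what has been measured and on what is new or still open speak of the compounds shown alone.

Measured compounds:
- Compound 1 `Cc1ccc(CC(CN/C(S)=N/Cc2ccc(NS(C)(=O)=O)cc2)COC(=O)c2ccccc2)cc1C` gives 410 nM in an assay on isolated protein for binding affinity to transient receptor potential cation channel subfamily V member 1 (Rattus norvegicus); on this read-out lower numbers stand for stronger inhibition and higher numbers for weaker inhibition.
- Compound 2 `COc1cc(C/N=C(\S)NCC(COC(=O)C(C)(C)C)Cc2ccc(C)c(C)c2)ccc1NS(C)(=O)=O` gives 49 nM in this assay.

Compound 2 stands at the lowest of the two numbers; compound 1 sits higher, beyond the scatter. Compound 3 `COc1cc(C/N=C(\S)NCC(COC(=O)c2ccccc2)Cc2ccc(C)c(C)c2)ccc1NS(C)(=O)=O` differs from compound 2 by phenyl in place of tert-butyl on a carbonyl carbon. For the measured compounds named here, no pair of measured compounds isolates this change, so its size is uncertain; a step of modest size is expected, not clearly beyond the scatter, estimated as a 1.4-fold higher number from compound 2 to compound 3 (0.15 log units; within the scatter). Compound 3 is therefore expected to give 70 nM, within a range of 25 nM to 200 nM.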

Compound 3, inhibition constant: 148 nM
The estimate for compound 3 lay 2.1-fold (0.33 log units) below the measured number; the range from low to high includes it.
By their numbers in this assay, from the lowest: compound 2; then compound 3; then compound 1.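

In this assay, swapping the ester group alone, phenyl in place of tert-butyl on a carbonyl carbon, gives a 3.0-fold higher number from compound 2 to compound 3 (0.48 log units; beyond the scatter) and so shows that this position responds to the change. With the benzoyl ester held constant, methoxy in place of hydrogen on an aromatic carbon gives a 2.8-fold lower number from compound 1 to compound 3 (0.44 log units; beyond the scatter) and separates this change from the ester change, which compounds 1 and 2 could not do. Nothing here gives a cause for either step.

As far as these compounds go, it remains open how a longer chain or a cyclohexyl ring on this carbonyl carbon would compare with tert-butyl and phenyl. Also open, from the compounds shown here alone, is how an ethoxy group or a chlorine atom would compare with the methoxy group.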